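This account rests on a few compounds, and the source may have more. Where it says the series, first, only, none or still open, it means among the compounds named here.

Of the compounds shown here, three have been measured in a functional assay on U2OS cells for antagonist activity at C-X-C chemokine receptor type 3 (Homo sapiens), read by beta-arrestin recruitment; a higher number here means a weaker inhibitor, a lower number a stronger inhibitor. Compound 1 `Cc1nc(-c2nc3ccccc3[nH]2)c(N2CCN(C(=O)Cn3cnc4cccnc43)[C@H](C)C2)s1` gives 1050 nM in this assay. Compound 2 `C[C@@H]1CN(c2sc(CO)nc2-c2nc3ccccc3[nH]2)CCN1C(=O)Cn1cnc2cccnc21` differs from compound 1 only by a hydroxy group on a saturated chain carbon bound to an aromatic carbon, and for compound 2 this assay reports only a limit, > 10000 nM, not a number. That single change gives an at least 9.5-fold higher number from compound 1 to compound 2 (0.97 log units; beyond the scatter), which rests on (the limit of > 10000 nM in this assay, at which 1 of the 3 values shown sits). Compound 3 `CCOc1ncc(-c2nc(C(F)(F)F)sc2N2CCN(C(=O)Cn3ncc4cccnc43)[C@H](C)C2)cn1` gives 55 nM in this assay, the lowest of the two numbers shown; the gap to compound 1 lies beyond the usual scatter.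

Compound 4 `CCOc1ncc(-c2nc(C(F)(F)F)sc2N2CCN(C(=O)Cn3cnc(C(F)(F)F)n3)[C@H](C)C2)cn1` is compound 3 with one change: a group of 9 heavy atoms (3 carbon, 3 nitrogen, 3 fluorine; one five-membered aromatic ring with 3 hetero atoms) in place of a group of 9 heavy atoms (6 carbon, 3 nitrogen; one five-membered aromatic ring with 2 hetero atoms, one six-membered aromatic ring with 1 hetero atom), on a saturated chain carbon bound to a carbonyl carbon. For the measured compounds named here, none of the measured steps touches this part of the molecule; the only measured step concerns a hydroxy group elsewhere. Nothing on hand therefore speaks to how a smaller, fluorinated five-membered ring in place of the fused two-ring group will change the result in this assay, and the expectation must stay wide. Compound 4 is expected to give about 150 nM in this assay, within a range from 30 nM to 1000 nM. That estimate means a step of a 2.7-fold higher number from compound 3 to compound 4 (0.44 log units; beyond the scatter), an expected mild weakening that might well fall inside the scatter.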

Compound 4, half-maximal inhibitory concentration: 118 nM
Beside the measured number, compound 4's estimate is 1.3-fold (0.10 log units) above it; low and high end bracket the measured number.
By their numbers in this assay, from the lowest: compound 3; then compound 4; then compound 1. At a limit, above all of these: compound 2.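

For the compounds shown here, the saturated chain carbon bound to a carbonyl carbon had not been varied among the earlier compounds, and here it takes a large change in this assay: replacing the fused two-ring group with 3-(trifluoromethyl)-1H-1,2,4-triazol-1-yl gives a 2.1-fold higher number from compound 3 to compound 4 (0.33 log units; beyond the scatter). This step is modest, though beyond the scatter, so in this pair a single five-membered ring can stand where the fused group stood at only a limited cost, with the two groups matching in heavy atoms and in hydrogen-bond acceptors. No measurement shown here bears on why the step has this size.

As far as these compounds go, this one pair cannot separate the loss of the six-membered ring from the arrival of the trifluoromethyl group, so it remains open how the same triazole would read with a methyl group, a nitrile or a plain hydrogen in place of trifluoromethyl. Also open, from the compounds shown here alone, is whether an amine or a carboxylic acid on the ring at this position would leave the number close to that of compound 4 118 nM or move it well away.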